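From pyrimidin-2-yl to pyrazin-2-yl on a sulfonamide nitrogen

This account rests on a few compounds, and the source may have more. Where it says the series, first, only, none or still open, it means among the compounds named here.

Measured so far in a physicochemical assay for solubility; a lower number here means a less soluble compound, a higher number a more soluble compound:
compound 1 `Cn1nccc1-c1cc(C(F)(F)F)ccc1[C@H]1CCOc2cc(S(=O)(=O)Nc3nccs3)ccc21` gives 83000 nM
compound 2 `Cn1nccc1-c1cc(C(F)(F)F)ccc1[C@H]1CCOc2cc(S(=O)(=O)Nc3ncccn3)ccc21` gives 532000 nM

Compound 2 holds the higher of the two numbers. Compound 3 `Cn1nccc1-c1cc(C(F)(F)F)ccc1[C@H]1CCOc2cc(S(=O)(=O)Nc3cnccn3)ccc21` has pyrazin-2-yl in place of pyrimidin-2-yl on a sulfonamide nitrogen. Within the data shown here, one measured step bears on this, made at the same place (a 6.4-fold higher number from compound 1 to compound 2 (0.81 log units; beyond the scatter)), and it is modest. It involves a different pair of groups, so it offers a scale but no direction. With compound 2 at the top of so short a series (532000 nM), a smaller move towards a lower number is expected (a 1.8-fold lower number from compound 2 to compound 3 (0.25 log units; within the scatter)). Compound 3 is estimated at 300000 nM (expected range 100000 nM to 700000 nM).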

Compound 3, solubility: 1170000 nM
Compound 3: middle estimate off by 3.9-fold (0.59 log units), on the low side; the measured number lies above the stated range.
By their numbers in this assay, from the lowest: compound 1; then compound 2; then compound 3.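

Pyrazin-2-yl and pyrimidin-2-yl have the same atoms and the same counts, yet this assay gives a 2.2-fold higher number from compound 2 to compound 3 (0.34 log units; beyond the scatter) on this sulfonamide nitrogen, so how the atoms are arranged within the ring matters here, not only which atoms it holds. Measured against 1,3-thiazol-2-yl, the range at this position widens to a 14-fold higher number from compound 1 to compound 3 (1.15 log units; beyond the scatter) and is now large. Nothing available explains either step.

The compounds leave open whether a pyridazin-3-yl or pyridin-2-yl group would extend this order, and whether it would hold if the trifluoromethyl group of the shared core were replaced by a nitrile.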